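Para Substituent Variation in a Biphenyl Amide Series

The source may report more compounds than this note shows. Statements on the series, on what has been measured and on what is new or still open speak of the compounds shown alone.

Compound 1, `CCc1ccc(-c2ccc(N(C[C@@H](N)[C@@H](C)CC)C(=O)[C@@H]3C[C@H]3c3ccccc3)cc2)cc1`, gives 44 nM in a functional assay for agonist activity at G protein-coupled receptor 88 (Homo sapiens), read by HTRF and cAMP accumulation; a higher number here means that more compound is needed for the effect, a lower number that less compound is needed.
Compound 2, `CC[C@H](C)[C@H](N)CN(C(=O)[C@@H]1C[C@H]1c1ccccc1)c1ccc(-c2ccc(C(F)(F)F)cc2)cc1`, gives 340 nM in this assay.
Compound 3, `CCOc1ccc(-c2ccc(N(C[C@@H](N)[C@@H](C)CC)C(=O)[C@@H]3C[C@H]3c3ccccc3)cc2)cc1`, gives 90 nM in this assay.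

Compound 3 holds the second highest of the three numbers: the step of a 2.0-fold higher number from compound 1 to compound 3 (0.31 log units; beyond the scatter) and the step of a 3.8-fold lower number from compound 2 to compound 3 (0.58 log units; beyond the scatter) place it between the other two. Compound 4, `CC[C@H](C)[C@H](N)CN(C(=O)[C@@H]1C[C@H]1c1ccccc1)c1ccc(-c2ccc(COC)cc2)cc1`, differs from compound 3 by methoxymethyl in place of ethoxy on an aromatic carbon. Going by the values given here, no measured step exchanges a group for the same atoms rearranged; the nearest comparisons, a 2.0-fold higher number from compound 1 to compound 3 (0.31 log units; beyond the scatter) and a 3.8-fold lower number from compound 2 to compound 3 (0.58 log units; beyond the scatter), were both modest. Compound 4 is therefore expected to land near compound 3, with a 1.3-fold higher number from compound 3 to compound 4 (0.12 log units; within the scatter) likely within the scatter. Compound 4 is estimated at 120 nM, with a range from 40 nM to 400 nM.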

Compound 4, half-maximal effective concentration: 35 nM
Compound 4: middle estimate off by 3.4-fold (0.54 log units), on the high side, and the stated range ends above it.
By their numbers in this assay, from the lowest: compounds 4 and 1 (each within the scatter of the next); then compound 3; then compound 2.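

Rearranging the same atoms at this position is not silent: a 2.6-fold lower number from compound 3 to compound 4 (0.41 log units; beyond the scatter) follows when methoxymethyl replaces ethoxy. Against the other groups, a 1.3-fold lower number from compound 1 to compound 4 (0.10 log units; within the scatter) leaves methoxymethyl level with ethyl, while a 9.7-fold lower number from compound 2 to compound 4 (0.99 log units; beyond the scatter) sets it clearly apart from trifluoromethyl. Nothing at hand explains why moving the oxygen within the group shifts the number. Still open, from the compounds shown here alone, is whether a longer chain such as ethoxymethyl, or an amine such as aminomethyl, would keep the number at this position close to that of compound 4.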